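A few compounds are considered here, and "the series" means these few. Any claim that something is new, unique, unknown or untested is made for them only; others in the source may bear on it.

Measured compounds:
compound 1 `CCCCCCOc1cccc(O)c1C(=O)/C=C/c1ccc(O)cc1`: > 30000 nM
compound 2 `O=C(/C=C/c1ccc(O)cc1)c1c(O)cccc1OCC1CCCCC1`: > 30000 nM
compound 3 `CC(C)COc1cccc(O)c1C(=O)/C=C/c1ccc(O)cc1`: 2970 nM

In a functional assay on PC-3 cells (Homo sapiens) for antiproliferative activity, read by sulforhodamine B assay (on this read-out lower numbers stand for stronger inhibition of growth and higher numbers for weaker inhibition of growth), compound 1 gives > 30000 nM, which is a limit of the assay and not a number. Compound 2 likewise gives only the limit > 30000 nM in this assay. Compound 3 gives a number, 2970 nM. Between compound 1 and compound 2 the step that the two limits leave unreadable from compound 1 to compound 2 cannot be read, because of the limit of > 30000 nM in this assay, at which 2 of the 3 values shown sit. Shortening the chain gives an at least 10-fold lower number from compound 1 to compound 3 (1.00 log units; beyond the scatter) and an at least 10-fold lower number from compound 2 to compound 3 (1.00 log units; beyond the scatter), so the smaller isopropyl leads to a clearly lower number than pentyl or cyclohexyl.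

Compound 4 `O=C(/C=C/c1ccc(O)cc1)c1c(O)cccc1OCCC1CCCC1` is not yet measured. It differs from compound 1 by cyclopentyl in place of butyl on a saturated chain carbon, two bonds along the chain from an oxygen on an aromatic ring; the same difference, cut one bond further out, reads hexyloxy to 2-cyclopentylethoxy. This keeps a large group on the chain, as in compound 1 and compound 2, so the expected step that the limit leaves unreadable from compound 1 to compound 4 is none beyond the scatter, and compound 4 is expected to reach only a limit again. Compound 4 is estimated at 40000 nM, in the range 10000 nM to 150000 nM.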

Compound 4, concentration for 50% growth inhibition: 3480 nM
For compound 4 the middle estimate is 11-fold (1.06 log units) above the measured one; the measured number lies below the stated range.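

In this assay, going from hexyloxy to 2-cyclopentylethoxy gives an at least 8.6-fold lower number from compound 1 to compound 4 (0.93 log units; beyond the scatter) and the change from the cyclohexyl group gives an at least 8.6-fold lower number from compound 2 to compound 4 (0.93 log units; beyond the scatter), so a large group carrying a ring at this position does not by itself leave a compound at the limit. Compound 1 and compound 2 each give a limit of the assay and not a number, so these two steps have only a minimum size: (the limit of > 30000 nM in this assay, at which 2 of the 4 values shown sit). The remaining step is a 1.2-fold higher number from compound 3 to compound 4 (0.07 log units; within the scatter), which means that a clear number here is not confined to the isopropyl end of the chain.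

Compound 2 and compound 4 differ in ring size and chain length together, so the compounds shown cannot separate those two changes. As far as these compounds go, how a chain ending in an amine or a carboxylic acid would read at this position also stays open.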